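Fluoro for methyl on a shared inactive core

The source may report more compounds than this note shows. Statements on the series, on what has been measured and on what is new or still open speak of the compounds shown alone.

Compound 3 `Cc1ccc(Cn2cc(CSC(=S)N3CCN(C(=O)OCc4ccccc4)CC3)nn2)cc1`: > 128000 nM
Compound 2 `COc1ccc(Cn2cc(CSC(=S)N3CCN(C(=O)OCc4ccccc4)CC3)nn2)cc1`: > 128000 nM
Compound 1 `Fc1ccc(Cn2cc(CSC(=S)N3CCNCC3)nn2)cc1`: > 128000 nM

In a functional assay on PC-3 cells (Homo sapiens) for inhibition, read by MTT assay, with a stated time of 72 h (on this read-out lower numbers stand for stronger inhibition and higher numbers for weaker inhibition), compound 3 reaches only the limit of the measurement, > 128000 nM, and no number. Compound 2 likewise gives only a limit, > 128000 nM. Compound 1 also gives only a limit, > 128000 nM. Going by the values given here, the one step between two compounds differing in a single place, a step that the two limits leave unreadable from compound 2 to compound 3, therefore cannot be read, since both ends sit at the limit (the limit of > 128000 nM in this assay, at which 3 of the 3 values shown sit).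

Compound 4 `O=C(OCc1ccccc1)N1CCN(C(=S)SCc2cn(Cc3ccc(F)cc3)nn2)CC1` is compound 3 with a small change: fluoro in place of methyl on an aromatic carbon. The change sits para to a large group. Among the compounds with values here, no measured step shows what swapping methyl for fluoro at this place does, and the same fluorobenzyl already sits in compound 1, which gives only a limit. The expected step that the limit leaves unreadable from compound 3 to compound 4 is none beyond the scatter, and compound 4 is expected to land again at a limit. The estimate for compound 4 is 200000 nM, within 128000 nM to 600000 nM.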

Compound 4, half-maximal inhibitory concentration: > 128000 nM
Compound 4 was reported as a limit (the forecaster's own chance of this, stated with the estimate: 85%); the middle value does not contradict the limit.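

Compound 4 gives only a limit in this assay, > 128000 nM. Its steps from compound 1, compound 2 and compound 3 therefore cannot be read: the limit of > 128000 nM in this assay, at which 4 of the 4 values shown sit.

The compounds shown leave open which change to the shared core, if any, would give a measurable value.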